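Indoline in place of phenoxymethyl on the piperazinone core

A few compounds are considered here, and "the series" means these few. Any claim that something is new, unique, unknown or untested is made for them only; others in the source may bear on it.

The shared core of compound 1 `COc1ccc2[nH]c(C(=O)N3CC(=O)N(Cc4ccccc4)[C@@H](COc4ccccc4)C3)cc2c1` carries a benzyl group and a phenoxymethyl arm on the six-membered non-aromatic ring with two nitrogens. In an ADME assay on Vero cells (Chlorocebus sabaeus) for cytotoxicity, with a stated time of 7 days (on this read-out higher numbers stand for lower toxicity in this test and lower numbers for higher toxicity in this test), compound 1 gives > 10000 nM, which is a limit of the assay and not a number (the limit of > 10000 nM in this assay, at which 1 of the 3 values shown sits). Compound 3 `COc1ccc2[nH]c(C(=O)N3CC(=O)N(Cc4ccccc4)[C@@H](N4CCC(Cc5ccccc5)CC4)C3)cc2c1` also ends at a limit in this assay, reported as > 30000 nM (the limit of > 30000 nM in this assay, at which 1 of the 3 values shown sits). Among the measured compounds shown here, compound 2 `O=C(c1cc2cc(C3CC3)ccc2[nH]1)N1CC(=O)N(Cc2ccccc2)[C@@H](CN2CCN(Cc3ccccc3)CC2)C1` is the one compound of the three with a number, giving 5500 nM in this assay. Compound 1 thus stands among limits, with only compound 2 showing a measured value below the limits.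

Compound 4 `COc1ccc2[nH]c(C(=O)N3CC(=O)N(Cc4ccccc4)[C@@H](N4CCc5ccccc54)C3)cc2c1` differs from compound 1 in a single place: 2,3-dihydro-1H-indol-1-yl in place of phenoxymethyl on a saturated ring carbon. For the measured compounds named here, no step between measured compounds is available for this change. Compound 4 is therefore expected to stay close to compound 1 in this assay, with a step from compound 1 to compound 4 of a step that the limit leaves unreadable from compound 1 to compound 4, not beyond the scatter. For compound 4 the estimate in this assay is 15000 nM, ranging from 5000 nM to 40000 nM.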

Compound 4, half-maximal cytotoxic concentration: > 100000 nM
Compound 4 was reported as a limit (the forecaster's own chance of this, stated with the estimate: 65%); at least 6.6-fold (0.82 log units) between middle value and limit.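

No step can be read between compound 1 and compound 4 in this assay: both results are limits of the assay and not numbers. The compounds shown leave open whether 2,3-dihydro-1H-indol-1-yl in place of phenoxymethyl changes the half-maximal cytotoxic concentration at all, and by how much.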